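This account rests on a few compounds, and the source may have more. Where it says the series, first, only, none or still open, it means among the compounds named here.

Compound 1 `COc1ccc(-c2nc3sc(-c4ccccc4)cn3n2)cc1`: 41%
Compound 2 `Clc1ccc(-c2cn3nc(-c4ccccc4)nc3s2)cc1`: 24%

Both compounds were tested in a functional assay on OVCAR-3 cells (Homo sapiens) for inhibition, read by sulforhodamine B assay, with a stated time of 48 h, tested at 10 uM; on this read-out higher numbers stand for more inhibition of growth at the one concentration tested and lower numbers for less inhibition of growth. In this assay, compound 2 gives 24%, the lower of the two numbers. Its nearest neighbour is compound 1 at 41%, and the gap between them lies beyond the usual scatter of repeated measurements.

The next compound to be measured is compound 3 `c1ccc(-c2nc3sc(-c4ccccc4)cn3n2)cc1`. It differs from compound 2 in one place: hydrogen in place of chloro on an aromatic carbon. In plain terms, hydrogen stands in place of chloro on an aromatic carbon, so 4-chlorophenyl becomes phenyl.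

Among the measured compounds shown here, no measured pair of compounds shows this exchange on its own, so there is no direct precedent for its size. For the measured compounds named here, the only guide is the span set by the two known values, and a single exchange of this kind gives no firm reason to expect a large move. A small rise in this assay, not beyond the scatter, is therefore the expectation. The expected a number 6 percentage points higher from compound 2 to compound 3 (within the scatter) is modest and upward. For compound 3, the estimated value is 30%, with an expected range from 14% to 47%.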

Compound 3, percent growth inhibition at one concentration: 16%
Compound 3: the middle estimate sits 14 percentage points above what was measured; low and high end bracket the measured number.
By their numbers in this assay, from the lowest: compounds 3 and 2 (each within the scatter of the next); then compound 1.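

In this assay, putting hydrogen in place of chloro gives a number 8 percentage points lower from compound 2 to compound 3 (within the scatter), so on this aromatic carbon the two cannot be told apart, and the 4-chlorophenyl group performs no differently from plain phenyl. Compound 3 also serves as the reference for the methoxy group, which sits on the other aromatic ring of the shared core: hydrogen in place of methoxy gives a number 25 percentage points lower from compound 1 to compound 3 (beyond the scatter), a step beyond the usual scatter, unlike the chloro exchange. The two exchanges therefore differ in both the group and the ring that carries it, and nothing measured here explains the larger step.

From the compounds shown here alone, it remains open whether the ring or the group matters more, since methoxy on the ring that carries chloro in compound 2 would be needed to separate the two. Going by these compounds, it is equally open whether an amine or a carboxylic acid on either ring would move the number further than methoxy does, or whether any such change would hold at other concentrations or in other cell lines.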